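From propyl to pentyl on a shared core

The source may hold more compounds than are shown below. What is called first, only, known or untested is meant among the compounds shown, and "the series" means these compounds.

In a functional assay on HeLa cells (Homo sapiens) for cytotoxicity, read by MTT assay, with a stated time of 24 h (a lower number here means a stronger inhibitor, a higher number a weaker inhibitor), the measured compounds give
Compound 1 `CCCCCCCCCCn1cc(-c2nc3ccccc3cc2C)nn1` gives 28.2 ug/mL
Compound 2 `CCCCCCCCCCn1cc(-c2nc3ccccc3cc2CC)nn1` gives > 100 ug/mL (a limit)
Compound 3 `CCCCCCCCCCn1cc(-c2nc3ccccc3cc2CCC)nn1` gives > 100 ug/mL (a limit)

Compound 3 carries propyl on the shared core and stands only at a limit (> 100 ug/mL). Compound 4 `CCCCCCCCCCn1cc(-c2nc3ccccc3cc2CCCCC)nn1` turns that propyl into pentyl (ethyl in place of hydrogen on a saturated chain carbon, three bonds along the chain from an aromatic carbon), with ethyl in place of hydrogen on a saturated chain carbon, three bonds along the chain from an aromatic carbon. Two measured steps give a direction (an at least 3.5-fold higher number from compound 1 to compound 2 (0.54 log units; beyond the scatter)) and (an at least 3.5-fold higher number from compound 1 to compound 3 (0.54 log units; beyond the scatter)), and each is at least modest and beyond the scatter. The closest step gives no size (a step that the two limits leave unreadable from compound 2 to compound 3). Given the weakening seen in (an at least 3.5-fold higher number from compound 1 to compound 3 (0.54 log units; beyond the scatter)), compound 4 is expected to remain a weak inhibitor, quite possibly at the same limit (the limit of > 100 ug/mL in this assay, at which 2 of the 3 values shown sit). No step beyond the scatter is expected (a step that the limit leaves unreadable from compound 3 to compound 4). Compound 4 is estimated at 120 ug/mL with 60 ug/mL to 250 ug/mL as its expected range.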

Compound 4, half-maximal inhibitory concentration: > 100 ug/mL
Compound 4 ended at the assay's limit; the forecaster's own chance of this, stated with the estimate: 80%; the middle value lies beyond the limit too.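

Extending the group on the shared core as far as pentyl does not bring back the inhibition that compound 1, with its methyl, shows in this assay: the gap remains, with an at least 3.5-fold higher number from compound 1 to compound 4 (0.54 log units; beyond the scatter). The steps among compound 2, compound 3 and compound 4 cannot be read, as each of these compounds stands only at a limit, so nothing shows whether lengthening the chain past ethyl changes anything further. At this position, the one readable contrast is still methyl against the three longer chains: the limit of > 100 ug/mL in this assay, at which 3 of the 4 values shown sit.

Open, going by these compounds, is whether a chain ending in an amine or a carboxylic acid at this position would give a number that can be read. Also open, on these data alone, is whether plain hydrogen in place of the methyl of compound 1 would give a lower number or a higher one.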